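The source may hold more compounds than are shown below. What is called first, only, known or untested is meant among the compounds shown, and "the series" means these compounds.

Measured values in an ADME assay on Vero cells (Chlorocebus sabaeus) for cytotoxicity, with a stated time of 7 days; on this read-out higher numbers stand for lower toxicity in this test and lower numbers for higher toxicity in this test:
compound 1 `COc1cccc(CN2C(=O)CN(C(=O)c3cc4cc(OC)ccc4o3)C[C@@H]2CCc2ccccc2)c1` gives 4500 nM
compound 2 `COc1ccc2[nH]c(C(=O)N3CC(=O)N(Cc4ccccc4)[C@@H](CN4CCC(C)CC4)C3)cc2c1` gives > 30000 nM

Compound 1 has a numbered reading. Compound 2 stands at a limit of this assay: its reading of > 30000 nM is a limit and not a number, the case recorded as the limit of > 30000 nM in this assay, at which 1 of the 2 values shown sits. Compound 3 `COc1ccc2[nH]c(C(=O)N3CC(=O)N(Cc4ccccc4)[C@@H](CN4CCc5ccccc5C4)C3)cc2c1` is the unmeasured analogue of compound 2 and differs from it in one place: 1,2,3,4-tetrahydroisoquinolin-2-yl in place of 4-methylpiperidin-1-yl on a saturated chain carbon bound to a saturated ring carbon. For the measured compounds named here, no step between measured compounds is available to calibrate this change, and nothing in the data shows what the entering group does to cytotoxicity. Because compound 2 sits at the limit of > 30000 nM in this assay, at which 1 of the 2 values shown sits, the expected step of an at least 1.2-fold lower number from compound 2 to compound 3 (0.07 log units; that floor lies within the scatter) in this assay is estimated as small, toward higher toxicity if anything, and possibly no more than the scatter. Compound 3 is therefore expected to give about 25000 nM, within a range from 8000 nM to 80000 nM, with a fair chance of again reading only as a limit.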

Compound 3, half-maximal cytotoxic concentration: 51800 nM
Estimate against measurement, compound 3: 2.1-fold (0.32 log units) below; low and high end bracket the measured number.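

No step from compound 2 to compound 3 can be read in this assay, because the reading of compound 2 is a limit and not a number: the limit of > 30000 nM in this assay, at which 1 of the 3 values shown sits.

The compounds shown leave open whether 1,2,3,4-tetrahydroisoquinolin-2-yl in place of 4-methylpiperidin-1-yl changes the reading in this assay at all, and in which direction.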